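The source may hold more compounds than are shown below. What is called first, only, known or untested is meant among the compounds shown, and "the series" means these compounds.

In an ADME assay on HEK293 cells (Homo sapiens) for cytotoxicity, read by MTT assay, with a stated time of 48 h (a lower number here means a stronger inhibitor, a higher number a weaker inhibitor), compound 3 `COc1ccc(N/C(CCNC2=CC(=O)c3ccccc3C2=O)=N\S(=O)(=O)c2ccc(C)cc2)cc1OC` gives 60600 nM, the highest of the three numbers shown, though all three lie within the scatter of one another: compound 2 `Cc1ccc(S(=O)(=O)/N=C(/CCNC2=CC(=O)c3ccccc3C2=O)Nc2cccc(C)c2)cc1` gives 56200 nM and compound 1 `Cc1ccc(S(=O)(=O)/N=C(/CCNC2=CC(=O)c3ccccc3C2=O)Nc2ccc(F)cc2)cc1` gives 55100 nM. Compound 4 `Cc1ccc(S(=O)(=O)/N=C(/CCNC2=CC(=O)c3ccccc3C2=O)Nc2ccc(Cl)cc2Cl)cc1` differs from compound 3 by 2,4-dichlorophenyl in place of 3,4-dimethoxyphenyl on an amine nitrogen. The measured steps that bear on swapping the aryl group on this nitrogen are a 1.1-fold higher number from compound 1 to compound 3 (0.04 log units; within the scatter), a 1.1-fold higher number from compound 2 to compound 3 (0.03 log units; within the scatter) and a 1.0-fold higher number from compound 1 to compound 2 (0.01 log units; within the scatter), each within the scatter. On that basis no step beyond the scatter is expected in this assay. The expected step is a 1.1-fold lower number from compound 3 to compound 4 (0.03 log units; within the scatter). Compound 4 is therefore estimated at 57000 nM in this assay, with a range from 30000 nM to 110000 nM.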

Compound 4, half-maximal inhibitory concentration: 41900 nM
Estimate against measurement, compound 4: 1.4-fold (0.13 log units) above; the measured number falls inside the stated range.
By their numbers in this assay, from the lowest: compounds 4, 1, 2 and 3 (each within the scatter of the next).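

In this assay the 2,4-dichlorophenyl group on this amine nitrogen stays within the scatter of all three earlier aryl groups (a 1.4-fold lower number from compound 3 to compound 4 (0.16 log units; within the scatter)), (a 1.3-fold lower number from compound 2 to compound 4 (0.13 log units; within the scatter)) and (a 1.3-fold lower number from compound 1 to compound 4 (0.12 log units; within the scatter)). The position therefore gives the same reading with a ring carrying two chlorine atoms and no hydrogen-bond acceptors as with 3,4-dimethoxyphenyl, which has two acceptors. Nothing available accounts for these numbers. Still open, as far as these compounds go, is whether any group here can produce a step beyond the scatter, such as a benzyl or cyclohexyl group, or an aryl ring bearing a carboxylic acid or an amine.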